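The source may report more compounds than this note shows. Statements on the series, on what has been measured and on what is new or still open speak of the compounds shown alone.

Measured compounds: compound 1 `O=C(Nc1cccc(-n2cc(-c3ccncc3)c(-c3cc(O)cc(Cl)c3)n2)c1)Nc1ccc(Cl)c(C(F)(F)F)c1` gives 88%; compound 2 `O=C(Nc1cccc(-n2cc(-c3ccncc3)c(-c3cc(O)cc(Cl)c3)n2)c1)Nc1ccc(Cl)c(Cl)c1` gives 95%; compound 3 `COc1cc(Cl)cc(-c2nn(-c3cccc(NC(=O)Nc4cc(C(F)(F)F)cc(C(F)(F)F)c4)c3)cc2-c2ccncc2)c1` gives 90%.

All three were read in a functional assay on HCT-15 cells (Homo sapiens) for inhibition, read by sulforhodamine B assay, with a stated time of 48 h, tested at 0.1 uM; on this read-out lower numbers stand for a stronger effect and higher numbers for a weaker effect at the one concentration tested. Compound 2 sits at the upper end of the three numbers, but its gap to compound 3 and its gap to compound 1 both fall within the scatter. Among the compounds with values here, the single measured step, a number 7 percentage points higher from compound 1 to compound 2 (within the scatter), is likewise within the scatter. Compound 4 `COc1cc(Cl)cc(-c2nn(-c3cccc(NC(=O)Nc4ccc(Cl)c(Cl)c4)c3)cc2-c2ccncc2)c1` is compound 2 with methyl in place of hydrogen on an oxygen on an aromatic ring. Within the data shown here, no measured pair isolates this change: compound 1 and compound 3 differ at this oxygen but also elsewhere, and their values stand close together. Nothing here points to a step beyond the scatter, so compound 4 is expected to show a number 3 percentage points lower from compound 2 to compound 4 (within the scatter), giving an estimated 92% within 80% to 102%.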

Compound 4, a percentage reported as activity, at one concentration (the size of the read-out at that concentration, not a potency): 53%
Compound 4: middle estimate off by 39 percentage points, on the high side, and the stated range ends above it.
By their numbers in this assay, from the lowest: compound 4; then compounds 1, 3 and 2 (each within the scatter of the next).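

In this assay, within the data shown here, the change from hydroxy to methoxy gives a number 42 percentage points lower from compound 2 to compound 4 (beyond the scatter) and is the first single change to go beyond the scatter. The earlier step, a number 7 percentage points higher from compound 1 to compound 2 (within the scatter) for chloro in place of trifluoromethyl, stayed within it, so this oxygen on the aromatic ring is the one place shown where a single change moves the read-out. No measurement at hand accounts for the size of this step. Open, on these data alone, is whether an ethoxy group or an amine at this place would read like methoxy, and whether methoxy would produce a similar step on compound 1.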